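The compounds below may be only part of what the source reports. "The series", "measured", "known", "first", "only" and "open" are said of these compounds alone.

For the measured compounds named here, compound 2 `Cc1cccc(NC(=O)c2cc(-c3cccc(F)c3)ccn2)n1` gives 500 nM in an assay on membranes from brain for displacement of a labelled ligand from metabotropic glutamate receptor 5 (Rattus norvegicus) (on this read-out lower numbers stand for stronger inhibition and higher numbers for weaker inhibition), and stands as the higher of the two numbers so far; compound 1 `Cc1cccc(NC(=O)c2cc(-c3cccc(C#N)c3)ccn2)n1` gives 320 nM in this assay, and the gap, a 1.6-fold higher number from compound 1 to compound 2 (0.19 log units; within the scatter), lies within the scatter. Compound 3 `Cc1cccc(NC(=O)c2cc(-c3cc(F)cc(F)c3)ccn2)n1` differs from compound 2 by fluoro in place of hydrogen on an aromatic carbon. Going by the values given here, no measured step repeats this change; the only step measured swaps one group for another on that ring and stays within the scatter. Accordingly, no step beyond the scatter is expected for compound 3, a 1.1-fold lower number from compound 2 to compound 3 (0.05 log units; within the scatter). Compound 3 is estimated at 450 nM, expected to fall between 150 nM and 1400 nM.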

Compound 3, inhibition constant: 43 nM
The estimate for compound 3 lay 10-fold (1.02 log units) above the measured number, and the stated range ends above it.
By their numbers in this assay, from the lowest: compound 3; then compounds 1 and 2 (each within the scatter of the next).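

In this assay, fluoro in place of hydrogen on this ring, turning 3-fluorophenyl into 3,5-difluorophenyl, gives a 12-fold lower number from compound 2 to compound 3 (1.07 log units; beyond the scatter) and so shows that this position can move the number well beyond the scatter, which the earlier cyano-to-fluoro step did not show. The change from 3-cyanophenyl to 3,5-difluorophenyl gives a 7.4-fold lower number from compound 1 to compound 3 (0.87 log units; beyond the scatter) as well. Nothing at hand explains the size of the step.

Open, on these data alone, is whether chloro, methoxy or an amine at this position would give a comparable number, and how the unsubstituted phenyl compares.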